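Cyclohexyl amide on a triazolotriazine piperazine: an expectation

The compounds below may be only part of what the source reports. "The series", "measured", "known", "first", "only" and "open" are said of these compounds alone.

Measured so far:
compound 1 `CN1CCN(c2nnc3nncn3n2)CC1` 8540 nM
compound 2 `CCC(=O)N1CCN(c2nnc3nncn3n2)CC1` 10100 nM
compound 3 `c1nnc2nnc(N3CCCCC3)nn12` 23600 nM

In a functional assay on HL-60 cells (Homo sapiens) for inhibition, read by MTT assay, with a stated time of 72 h (on this read-out lower numbers stand for stronger inhibition and higher numbers for weaker inhibition), compound 2 gives 10100 nM, the second highest of the three numbers; compound 1 is nearest at 8540 nM, compound 3 furthest at 23600 nM. Compound 4 `O=C(C1CCCCC1)N1CCN(c2nnc3nncn3n2)CC1` differs from compound 2 by cyclohexyl in place of ethyl on a carbonyl carbon. For the measured compounds named here, the only measured step touching the substituent on the piperazine nitrogen is a 1.2-fold higher number from compound 1 to compound 2 (0.07 log units; within the scatter), which did not move the number beyond the scatter. Nothing measured bears on a cyclohexyl here, so compound 4 is expected to stay close to compound 2, with a 1.0-fold lower number from compound 2 to compound 4 (0.00 log units; within the scatter). Compound 4 is estimated at 10000 nM, between 4000 nM and 25000 nM.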

Compound 4, half-maximal inhibitory concentration: 1160 nM
Beside the measured number, compound 4's estimate is 8.6-fold (0.94 log units) above it; the measured number lies below the stated range.
By their numbers in this assay, from the lowest: compound 4; then compounds 1 and 2 (each within the scatter of the next); then compound 3.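

On the carbonyl carbon, cyclohexyl in place of ethyl gives an 8.7-fold lower number from compound 2 to compound 4 (0.94 log units; beyond the scatter) in this assay. This position therefore responds to the group it carries, which the earlier step on the same nitrogen, a 1.2-fold higher number from compound 1 to compound 2 (0.07 log units; within the scatter), did not show. No evidence is available to explain this step.

The compounds shown leave open whether the ring itself or simply the larger number of carbons matters. An open hexyl chain, a cyclopentyl or a phenyl on this carbonyl carbon would bear on that question.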